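A few compounds are considered here, and "the series" means these few. Any claim that something is new, unique, unknown or untested is made for them only; others in the source may bear on it.

Working notes on the phenyl carbamate series.

Of the compounds shown here, three have been measured in an assay on microsomes from brain (strain Sprague-Dawley) for inhibition of Fatty-acid amide hydrolase 1 (Rattus norvegicus), read by fluorescence and HPLC, with stated times of 10 min and 60 min; a higher number here means a weaker inhibitor, a lower number a stronger inhibitor. Compound 1 `Cc1cc(-c2ccccc2)c(-c2ccccc2)n1CCCCCCNC(=O)Oc1ccccc1` gives 2600 nM; compound 2 `O=C(NCCCCCCn1ncc2ccccc21)Oc1ccccc1` gives 920 nM; compound 3 `Cc1ccc(-c2ccccc2)n1CCCCCCNC(=O)Oc1ccccc1` gives 310 nM. Among the compounds with values here, compound 3 therefore stands at the lowest number of the three measured so far, with compound 2 at a higher number and compound 1 furthest away. Within the set there is one single-point step: an 8.4-fold lower number from compound 1 to compound 3 (0.92 log units; beyond the scatter).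

The next compound, compound 4 `Cc1c(-c2ccccc2)cc(-c2ccccc2)n1CCCCCCNC(=O)Oc1ccccc1`, differs from compound 3 as follows: phenyl in place of hydrogen on an aromatic carbon. The phenyl enters on the aromatic carbon next to the ring atom that bears a methyl group, two ring bonds from the ring atom that bears a phenyl group.

Within the data shown here, only the step between compound 1 and compound 3 bears directly on this change, and it runs the other way: taking a phenyl off an aromatic carbon of the same five-membered ring gave an 8.4-fold lower number from compound 1 to compound 3 (0.92 log units; beyond the scatter). Among the measured compounds shown here, putting a phenyl back onto that ring, at a different carbon, is expected to raise the number in this assay again, and a step of comparable size is the working expectation, though the position differs and the data give no second example. For compound 4 the expected result in this assay is 1500 nM, with a plausible range of 500 nM to 4500 nM, which corresponds to an expected step of a 4.8-fold higher number from compound 3 to compound 4 (0.68 log units; beyond the scatter).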

Compound 4, half-maximal inhibitory concentration: 460 nM
For compound 4 the middle estimate is 3.3-fold (0.51 log units) above the measured one, and the stated range ends above it.
By their numbers in this assay, from the lowest: compounds 3, 4 and 2 (each within the scatter of the next, the first and the last beyond it); then compound 1.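

In this assay, phenyl in place of hydrogen on the aromatic carbon next to the ring atom that bears a methyl group gives a 1.5-fold higher number from compound 3 to compound 4 (0.17 log units; within the scatter) and so leaves the number at this position within the usual scatter. The earlier phenyl-for-hydrogen pair on this ring involves a different carbon and reads as an 8.4-fold lower number from compound 1 to compound 3 (0.92 log units; beyond the scatter) in the direction that removes the phenyl, a step beyond the scatter, so across these two steps the outcome of this change depends on which aromatic carbon carries the phenyl. Nothing in hand explains why the two carbons behave differently.

Hydrogen and phenyl are the only groups shown at this carbon, so it remains open whether a carboxylic acid, an amine or a single methyl group there would also stay within the scatter of compound 3. Also open, going by these compounds, is whether the phenyl at this carbon would give a similar step with the methyl group removed from the neighbouring ring atom, or with a longer chain on the ring nitrogen.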